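Diaryl urea series: dichlorophenyl analogue of compound 2

This account rests on a few compounds, and the source may have more. Where it says the series, first, only, none or still open, it means among the compounds named here.

Compound 2 `COc1cc2cc(Oc3ccc(NC(=O)Nc4cccc(C(F)(F)F)c4)cc3)c(C)nc2cc1OC` is the lower of the two numbers measured in a functional assay on MCF7 cells (Homo sapiens) for inhibition, read by sulforhodamine B assay, with a stated time of 48 h, tested at 10 uM; a higher number here means a weaker effect of the compound at the concentration tested, a lower number a stronger effect; there compound 2 gives 6.81%. Compound 1 `COc1cc2cc(Oc3ccc(NC(=O)Nc4ccc(C)cc4)cc3)c(C)nc2cc1OC`, which carries 4-methylphenyl on the amide-type nitrogen, gives 94.5% in this assay, and the step of a number 87.7 percentage points lower from compound 1 to compound 2 (beyond the scatter) is the only one measured so far. Compound 3 `COc1cc2cc(Oc3ccc(NC(=O)Nc4ccc(Cl)c(Cl)c4)cc3)c(C)nc2cc1OC` is not yet measured; its change from compound 2 is 3,4-dichlorophenyl in place of 3-(trifluoromethyl)phenyl on an amide-type nitrogen. Among the measured compounds shown here, no measured step involves 3,4-dichlorophenyl, so the single step from compound 1 to compound 2 bears on it only indirectly: it shows that the group on this nitrogen can move the read-out in this assay by a large amount, but it gives no direct guide for this substituent. The expectation for compound 3 is therefore a step of a number 8.2 percentage points higher from compound 2 to compound 3 (within the scatter) in this assay, probably within the scatter or somewhat higher, since compound 2 at 6.81% leaves little room lower. Compound 3 is estimated at 15%, with a range from 3% to 55%.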

Compound 3, a percentage reported as activity, at one concentration (the size of the read-out at that concentration, not a potency): 13.8%
The estimate for compound 3 lay 1.2 percentage points above the measured number, and the stated range covers the measured number.
By their numbers in this assay, from the lowest: compounds 2 and 3 (each within the scatter of the next); then compound 1.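

In this assay, 3,4-dichlorophenyl in place of 3-(trifluoromethyl)phenyl on the amide-type nitrogen gives a number 7 percentage points higher from compound 2 to compound 3 (within the scatter) and so does not separate these two groups. The other step, a number 80.7 percentage points lower from compound 1 to compound 3 (beyond the scatter), shows that the large gap from the 4-methylphenyl urea is not confined to 3-(trifluoromethyl)phenyl, since a second, differently substituted phenyl group also stands far from compound 1. Nothing at hand gives a reason for this pattern.

Open, going by these compounds, is how plain phenyl, or a phenyl carrying a nitrile, a methoxy group or a carboxylic acid, would read at this nitrogen. Also open, on these data alone, is how compound 2 and compound 3 compare in potency, as the read-out gives only the size of the effect at one concentration.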